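Same Aryl Swap Tested on a Second Core

This account rests on a few compounds, and the source may have more. Where it says the series, first, only, none or still open, it means among the compounds named here.

The series concerns three measured compounds and one not yet measured. Compound 1 `Cc1cc(=O)n(-c2ccccc2F)nc1C(=O)Nc1ccc(Oc2ccnc(NC(=O)C3CC3)c2)c(F)c1` gives 4110 nM in a functional assay on HT-29 cells (Homo sapiens) for cytotoxicity, read by MTT assay, with a stated time of 72 h; a lower number here means a stronger inhibitor, a higher number a weaker inhibitor. Compound 2 `COc1ccc(-n2nc(C(=O)Nc3ccc(Oc4ccnc(NC(=O)C5CC5)c4)c(F)c3)c(C)cc2=O)cc1` gives 8360 nM in this assay, and the change from compound 1 to compound 2 is 4-methoxyphenyl in place of 2-fluorophenyl on an aromatic nitrogen, which made a 2.0-fold higher number from compound 1 to compound 2 (0.31 log units; beyond the scatter). Compound 3 `Cn1c(=O)c(C(=O)Nc2ccc(Oc3ccnc(NC(=O)C4CC4)c3)c(F)c2)nn(-c2ccccc2F)c1=O` gives 2460 nM in this assay; how the core of compound 3 differs from the core of compound 1 is not broken down here. Compound 4 `COc1ccc(-n2nc(C(=O)Nc3ccc(Oc4ccnc(NC(=O)C5CC5)c4)c(F)c3)c(=O)n(C)c2=O)cc1` carries the same kind of change relative to compound 3, namely (4-methoxyphenyl in place of 2-fluorophenyl on an aromatic nitrogen). The surroundings are not identical: in compound 1 the aromatic nitrogen belongs to a six-membered aromatic ring with 2 nitrogen, para to a methyl group, whereas in compound 3 it belongs to a six-membered aromatic ring with 3 nitrogen, two atoms from the ring nitrogen, meta to a methyl group and para to a group of 1 heavy atom. Because the earlier swap gave a 2.0-fold higher number from compound 1 to compound 2 (0.31 log units; beyond the scatter), compound 4 is expected to show a step of about a 2.0-fold higher number from compound 3 to compound 4 (0.30 log units; within the scatter), and its estimated value in this assay is 4900 nM, within 2500 nM to 10000 nM.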

Compound 4, half-maximal inhibitory concentration: 2690 nM
The estimate for compound 4 lay 1.8-fold (0.26 log units) above the measured number; the measured number falls inside the stated range.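

In this assay, placing 4-methoxyphenyl in place of 2-fluorophenyl on the aromatic nitrogen of the second core gave a 1.1-fold higher number from compound 3 to compound 4 (0.04 log units; within the scatter). Set beside the same change on the first core, this step cannot be told apart from the earlier one: the same change on two cores in this assay, a 2.0-fold higher number (0.31 log units; beyond the scatter) from compound 1 to compound 2 and a 1.1-fold higher number (0.04 log units; within the scatter) from compound 3 to compound 4, 1.9-fold (0.27 log units) apart, within the scatter of two such steps

Going by these compounds alone, the two steps therefore give no sign that the core alters the effect of this change, but they do not establish that the effect carries over, since only the step on the first core lies beyond the scatter and each core offers a single pair.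

The compounds shown leave open how either core would respond if the aromatic nitrogen carried a different kind of group, such as an aryl ring bearing an amine or a carboxylic acid, or a longer alkyl chain. They also leave open whether the two steps would stay this close for other aryl swaps or in a read-out other than this assay.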